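A few compounds are considered here, and "the series" means these few. Any claim that something is new, unique, unknown or untested is made for them only; others in the source may bear on it.

Compounds measured so far:
compound 1 `Cc1cccc(-c2cc(-c3ccc(Cl)o3)cc(-c3ccsc3)n2)c1`: 7.5%
compound 2 `Cc1ccccc1-c1cc(-c2ccc(Cl)o2)cc(-c2ccsc2)n1`: 6.7%

Both numbers come from an assay on isolated protein for inhibition of DNA topoisomerase 1 (Homo sapiens), tested at 100 uM; on this read-out higher numbers stand for a stronger effect at the one concentration tested and lower numbers for a weaker effect. For the measured compounds named here, compound 2 stands alongside compound 1 there; the only measured step, a number 0.8 percentage points lower from compound 1 to compound 2 (within the scatter), lies within the scatter. Compound 3 `Cc1ccc(-c2cc(-c3ccc(Cl)o3)cc(-c3ccsc3)n2)o1` differs from compound 2 in one place: 5-methylfuran-2-yl in place of 2-methylphenyl on an aromatic carbon. Going by the values given here, no measured step exchanges a six-membered carbon ring for a five-membered ring with one hetero atom next to the ring nitrogen, so that single step, a number 0.8 percentage points lower from compound 1 to compound 2 (within the scatter), bears on it only loosely and was itself within the scatter. Compound 3 is therefore expected to remain near compound 2, with a number 0.3 percentage points higher from compound 2 to compound 3 (within the scatter) not beyond the scatter. The estimate for compound 3 in this assay is 7%, between 0% and 18%.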

Compound 3, a percentage reported as inhibition, at one concentration (the size of the read-out at that concentration, not a potency): 9.1%
Estimate against measurement, compound 3: 2.1 percentage points below, within the range that was stated.
By their numbers in this assay, from the lowest: compounds 2, 1 and 3 (each within the scatter of the next).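

In this assay, the position next to the ring nitrogen also accepts a five-membered aromatic ring with 1 hetero atom in place of a six-membered carbon ring, with a number 2.4 percentage points higher from compound 2 to compound 3 (within the scatter) and a number 1.6 percentage points higher from compound 1 to compound 3 (within the scatter). Neither exchange of the ring, nor the hydrogen-bond acceptor that enters with 5-methylfuran-2-yl, gives a step beyond the scatter here. No measured evidence bears on this result. 

The compounds shown leave open whether any group at this position, such as an amine or a carboxylic acid, would give a step beyond the scatter. They also leave open what the 5-chlorofuran-2-yl and thiophen-3-yl groups contribute.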